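Purine ribosides against the nucleoside transporter: series notes

The source may hold more compounds than are shown below. What is called first, only, known or untested is meant among the compounds shown, and "the series" means these compounds.

Measured so far:
Compound 1, `CCCCCNc1ncnc2c1ncn2[C@@H]1O[C@H](CO)[C@@H](O)[C@H]1O`: 13500 nM
Compound 2, `CCCn1cnc2c(SCc3ccccn3)nc(N)nc21`: 91200 nM
Compound 3, `CC(=O)c1ccccc1Sc1nc(N)nc2c1ncn2[C@@H]1O[C@H](CO)[C@@H](O)[C@H]1O`: 447000 nM

In an assay on isolated protein for binding affinity to Equilibrative nucleoside transporter 1 (Homo sapiens) (a higher number here means a weaker inhibitor, a lower number a stronger inhibitor), compound 1 gives the lowest of the three numbers; compound 2 and compound 3 both lie beyond the scatter above it, compound 3 furthest. The next step keeps the core of compound 1 and changes one group: compound 4, `OC[C@H]1O[C@@H](n2cnc3c(CSc4ccc(F)cc4)ncnc32)[C@H](O)[C@@H]1O`, carries ((4-fluorophenyl)sulfanyl)methyl in place of pentylamino on an aromatic carbon. Within the data shown here, no measured pair shows this change, so its size is unknown here. A move of the ribose-bearing series toward a sulfur-linked aryl group is expected to help rather than hurt, and the step from compound 1 to compound 4 in this assay is estimated as a 4.5-fold lower number from compound 1 to compound 4 (0.65 log units; beyond the scatter), a gain beyond the scatter. For compound 4 the expected value in this assay is 3000 nM, with a range from 300 nM to 30000 nM.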

Compound 4, half-maximal inhibitory concentration: 158 nM
Beside the measured number, compound 4's estimate is 19-fold (1.28 log units) above it; the whole stated range lies above it.
By their numbers in this assay, from the lowest: compound 4; then compound 1; then compound 2; then compound 3.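

In this assay, ((4-fluorophenyl)sulfanyl)methyl in place of pentylamino on this aromatic carbon gives an 85-fold lower number from compound 1 to compound 4 (1.93 log units; beyond the scatter), so the number at this position of the shared core responds strongly to the group it carries. The entering group has no hydrogen-bond donor, so a donor at this place is not needed for compound 4 to reach 158 nM in this assay. On these data alone, it remains open whether the sulfur, the fluorine or the aromatic ring accounts for the step, and whether an unsubstituted phenyl or a benzylamino group here would do as well. Nothing at hand explains the size of this step.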